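Shifting the methyl on the phenyl of compound 2

A few compounds are considered here, and "the series" means these few. Any claim that something is new, unique, unknown or untested is made for them only; others in the source may bear on it.

Two members of the series have numbers in a functional assay on HCT-116 cells (Homo sapiens) for inhibition, read by MTT assay, with a stated time of 24 h, tested at 2.5 uM; on this read-out lower numbers stand for less inhibition of growth and higher numbers for more inhibition of growth at the one concentration tested. Compound 1 `CS(=O)(=O)c1ccc(-c2cnc3[nH]cc(-c4nnc(-c5ccc(Cl)cc5)o4)c(=O)c3c2)cc1` gives 2.06%. Compound 2 `Cc1ccc(-c2nnc(-c3c[nH]c4ncc(-c5ccc(S(C)(=O)=O)cc5)cc4c3=O)o2)cc1` gives 7.47%, the larger of the two numbers, with compound 1 as its nearest neighbour, yet the step of a number 5.4 percentage points higher from compound 1 to compound 2 (within the scatter) stays within the scatter, so the two stand level. Compound 3 `Cc1cccc(-c2nnc(-c3c[nH]c4ncc(-c5ccc(S(C)(=O)=O)cc5)cc4c3=O)o2)c1` is not yet measured. It differs from compound 2 in one place: 3-methylphenyl in place of 4-methylphenyl on an aromatic carbon. Among the compounds with values here, no measured step touches this change; the only measured step, from chloro to methyl, says nothing about the position of a methyl on the phenyl, and both measured numbers are low. On that basis no step beyond the scatter is expected in this assay, and the expected step of a number 0.5 percentage points lower from compound 2 to compound 3 (within the scatter) is essentially flat. Compound 3 is therefore estimated at 7%, with a range from -5% to 20%.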

Compound 3, percent growth inhibition at one concentration: 8.13%
Estimate against measurement, compound 3: 1.1 percentage points below, within the range that was stated.
By their numbers in this assay, from the lowest: compounds 1, 2 and 3 (each within the scatter of the next).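

In this assay, 3-methylphenyl in place of 4-methylphenyl on the aromatic carbon of the five-membered ring gives a number 0.7 percentage points higher from compound 2 to compound 3 (within the scatter), so where the methyl sits on this phenyl makes no readable difference at the one concentration tested. The wider change, 3-methylphenyl in place of 4-chlorophenyl on the same carbon, gives a number 6.1 percentage points higher from compound 1 to compound 3 (within the scatter) and also leaves the pair level, so all three compounds stand together with low numbers. No measurement given here bears on the reason for this flat result.

The compounds shown leave open whether a different kind of group on this phenyl, such as an amine, a carboxylic acid or a longer chain, would move the number beyond the scatter. On these data alone, whether the three compounds also stand level at a higher concentration remains open too.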